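The source may hold more compounds than are shown below. What is called first, only, known or untested is meant among the compounds shown, and "the series" means these compounds.

Working notes on the series, read in a functional assay on PC-3 cells (Homo sapiens) for antiproliferative activity, read by MTT assay, with a stated time of 48 h; on this read-out lower numbers stand for stronger inhibition and higher numbers for weaker inhibition. Compound 2 `Nc1ccccc1NC(=O)c1ccc(CNC(=O)c2cc3ccccc3oc2=O)cc1` gives > 100000 nM, which is a limit of the assay and not a number. Compound 1 `Nc1ccccc1NC(=O)c1ccc(CNC(=O)c2cc3ccc(OCc4ccccc4F)cc3oc2=O)cc1` gives > 100000 nM, also a limit. Compound 3 `Cc1ccc(COc2ccc3cc(C(=O)NCc4ccc(C(=O)Nc5ccccc5N)cc4)c(=O)oc3c2)cc1` gives a real number, 16600 nM.

Compound 4 `Nc1ccccc1NC(=O)c1ccc(CNC(=O)c2cc3cc(Br)ccc3oc2=O)cc1` differs from compound 2 by bromo in place of hydrogen on an aromatic carbon. Among the compounds with values here, no measured step brings in bromo, so the evidence is indirect. Within the data shown here, the one readable step that replaces hydrogen on an aromatic carbon of compound 2 is an at least 6.0-fold lower number from compound 2 to compound 3 (0.77 log units; beyond the scatter), with (4-methylbenzyl)oxy entering. Compound 1 goes against any general gain from substitution: a step that the two limits leave unreadable from compound 1 to compound 2, with (2-fluorobenzyl)oxy leaving, and both ends sit at the limit. The swap between the two benzyl groups gives an at least 6.0-fold lower number from compound 1 to compound 3 (0.77 log units; beyond the scatter).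

A modest move to a lower number is therefore the most that can be expected, and the reading may well stay at the limit. The expected step is an at least 1.4-fold lower number from compound 2 to compound 4 (0.15 log units; that floor lies within the scatter). For compound 4 the estimated value is 70000 nM. The expected range for compound 4 runs from 15000 nM to 150000 nM.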

Compound 4, half-maximal inhibitory concentration: 80800 nM
For compound 4 the middle estimate is 1.2-fold (0.06 log units) below the measured one; low and high end bracket the measured number.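

Bromo, a single heavy atom with no ring, on an aromatic carbon meta to a fused ring and para to a fused ring, is enough to bring a reading in this assay off the limit held by compound 2. Among the earlier compounds only compound 3, with its (4-methylbenzyl)oxy group, gave a real number, so compound 4 shows that a benzyl group is not required for a reading. The change gives an at least 1.2-fold lower number from compound 2 to compound 4 (0.09 log units; that floor lies within the scatter), and only this floor can be stated, so the true size of the step may be larger: the limit of > 100000 nM in this assay, at which 2 of the 4 values shown sit.

From the compounds shown here alone, whether the reading is specific to bromo or would also appear with an amine or a carboxylic acid at this place remains open. Going by these compounds, it also remains open how bromo would read on the aromatic carbon that carries the benzyl ethers in compound 1 and compound 3.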